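The source may hold more compounds than are shown below. What is called first, only, known or untested is meant among the compounds shown, and "the series" means these compounds.

Measured compounds in a functional assay on MDA-MB-231 cells (Homo sapiens) for inhibition, read by MTT assay, with a stated time of 48 h; a higher number here means a weaker inhibitor, a lower number a stronger inhibitor:
- compound 1 `COc1cc(-c2cc(-c3ccc(N)cc3)nc(-c3ccccc3)n2)cc(OC)c1OC` gives 1010 nM
- compound 2 `COc1cc(-c2cc(-c3ccc(Br)cc3)nc(-c3ccccc3)n2)cc(OC)c1OC` gives only a limit, > 25000 nM
- compound 3 `COc1cc(-c2cc(-c3cccc(O)c3)nc(-c3ccccc3)n2)cc(OC)c1OC` gives 1990 nM

Going by the values given here, compound 2 stands at the limit of this assay and has no number of its own; it is the one of the three values that sits at the limit of > 25000 nM in this assay, at which 1 of the 3 values shown sits. Both measured steps away from it are large: an at least 24-fold higher number from compound 1 to compound 2 (1.39 log units; beyond the scatter) and an at least 12-fold lower number from compound 2 to compound 3 (1.09 log units; beyond the scatter). The step from compound 1 to compound 3 is different in kind, since a 2.0-fold higher number from compound 1 to compound 3 (0.29 log units; within the scatter).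

Compound 4 `COc1cc(-c2cc(-c3cccc4ccccc34)nc(-c3ccccc3)n2)cc(OC)c1OC` differs from compound 2 by naphthalen-1-yl in place of 4-bromophenyl on an aromatic carbon. The two measured steps that bear on this change both leave compound 2 and both end in a group with a hydrogen-bond donor, whereas the entering naphthalen-1-yl has 0 hydrogen-bond donors and 0 hydrogen-bond acceptors, as does the leaving 4-bromophenyl. Among the compounds with values here, no measured step tests such a change, so the large gains seen for compound 1 and compound 3 are not expected to carry over, and compound 4 is expected to stay near the limit where compound 2 sits. The step of an at least 1.6-fold lower number from compound 2 to compound 4 (0.22 log units; that floor lies within the scatter) is therefore the expected outcome. For compound 4 the estimate is 15000 nM, with a range from 2000 nM to 60000 nM.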

Compound 4, half-maximal inhibitory concentration: 3240 nM
For compound 4 the middle estimate is 4.6-fold (0.67 log units) above the measured one, within the range that was stated.
By their numbers in this assay, from the lowest: compounds 1, 3 and 4 (each within the scatter of the next, the first and the last beyond it). At a limit, above all of these: compound 2.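

In this assay, a hydrogen-bond donor on the entering group is not needed to leave the limit at this position: naphthalen-1-yl has 0 hydrogen-bond donors, as does 4-bromophenyl, yet the change gives an at least 7.7-fold lower number from compound 2 to compound 4 (0.88 log units; beyond the scatter). The size of that step is a floor, since compound 2 has no number of its own and carries only a limit: the limit of > 25000 nM in this assay, at which 1 of the 4 values shown sits. Set against the donor-bearing groups, naphthalen-1-yl gives a 1.6-fold higher number from compound 3 to compound 4 (0.21 log units; within the scatter) from 3-hydroxyphenyl and a 3.2-fold higher number from compound 1 to compound 4 (0.51 log units; beyond the scatter) from 4-aminophenyl, so among these compounds a donor is not essential, although 4-aminophenyl keeps a measurable margin over naphthalen-1-yl.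

The compounds shown do not separate the effect of the second aromatic ring in naphthalen-1-yl from the effect of removing the bromine, a question that unsubstituted phenyl, 4-chlorophenyl or naphthalen-2-yl at the same carbon would address. They also leave open whether 4-aminophenyl's margin depends on the amine itself, which 4-methoxyphenyl, 4-dimethylaminophenyl or 3-aminophenyl would test, and whether any of this holds with another group in place of the phenyl group on the shared core.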